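Sulfonamide amine variation on the trifluoromethyl hydroxy amide

A few compounds are considered here, and "the series" means these few. Any claim that something is new, unique, unknown or untested is made for them only; others in the source may bear on it.

The series shares one core, a para-substituted anilide of a trifluoromethyl hydroxy propanamide carrying a sulfonyl group on the ring. Compound 1 is `CCC(C)N(C(C)CC)S(=O)(=O)c1ccc(NC(=O)C(C)(O)C(F)(F)F)cc1` and in an assay on a protein complex (Cavia porcellus) with sulfonylurea receptors; K-ATP channels (Homo sapiens) as the target (a lower number here means a stronger inhibitor, a higher number a weaker inhibitor), compound 1 gives > 30000 nM, which is a limit of the assay rather than a number, as noted in the limit of > 30000 nM in this assay, at which 1 of the 2 values shown sits. Compound 2 is `CC(O)(C(=O)Nc1ccc(S(=O)(=O)N2CCOCC2)cc1)C(F)(F)F` and in this assay compound 2 gives 5850 nM. For the measured compounds named here, the step of an at least 5.1-fold lower number from compound 1 to compound 2 (0.70 log units; beyond the scatter) is the only measured step so far. Going by the values given here, compound 2 therefore stands as the single numerical value in this assay, with the other entry a limit.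

Compound 3 is `CC(O)(C(=O)Nc1ccc(S(=O)(=O)N2CCCCC2)cc1)C(F)(F)F` and is to be measured in this assay. It differs from compound 2 as follows: piperidin-1-yl in place of morpholin-4-yl on a sulfonyl sulfur. The measured step from compound 1 to compound 2 concerns the same sulfonyl sulfur but a different amine, so it shows only that this position can move the number; it gives no direction for the present change. For compound 3 a step within the scatter is expected, a 1.3-fold lower number from compound 2 to compound 3 (0.11 log units; within the scatter), so compound 3 is estimated at 4500 nM, with a range from 1500 nM to 13000 nM.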

Compound 3, half-maximal inhibitory concentration: 9250 nM
For compound 3 the middle estimate is 2.1-fold (0.31 log units) below the measured one; low and high end bracket the measured number.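

Replacing morpholin-4-yl with piperidin-1-yl on the sulfonyl sulfur gives a 1.6-fold higher number from compound 2 to compound 3 (0.20 log units; within the scatter), so the two rings are not separated in this assay, and the ring oxygen and hydrogen-bond acceptor that leave with morpholin-4-yl have no readable effect on the number. The earlier step rested on morpholin-4-yl alone, whereas an at least 3.2-fold lower number from compound 1 to compound 3 (0.51 log units; beyond the scatter) shows that a ring without that oxygen also stands apart from bis(sec-butyl)amino, so the separation from compound 1 does not depend on the ring oxygen. The entry for compound 1 is a limit of the assay and not a number, which makes this step a minimum only: the limit of > 30000 nM in this assay, at which 1 of the 3 values shown sits.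

The compounds shown do not say whether the six-membered ring itself matters, since each ring here has the same size and no smaller ring such as pyrrolidin-1-yl or open-chain dimethylamino group appears for comparison with bis(sec-butyl)amino. Also open, as far as these compounds go, is how a second ring nitrogen, as in piperazin-1-yl, or a carboxylic acid on the piperidine ring would read in this assay.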